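The source may report more compounds than this note shows. Statements on the series, on what has been measured and on what is new or still open speak of the compounds shown alone.

Measured so far in a functional assay on DMS-273 cells (Homo sapiens) for inhibition, read by sulforhodamine B assay, with a stated time of 48 h; a higher number here means a weaker inhibitor of growth, a lower number a stronger inhibitor of growth:
Compound 1 `CCCCCCCCCCCC[C@@H](O)[C@H]1CC[C@H]([C@H](O)CCCCCCCCCCNC(=O)c2ccnn2C)O1`: 5750 nM
Compound 2 `CCCCCCCCCCCC[C@@H](O)[C@H]1CC[C@H]([C@H](O)CCCCCCCCCCNCc2ccnn2C)O1`: 1580 nM

Of these two compounds, compound 2 has the lower number, at 1580 nM, and so is the stronger inhibitor of growth in this assay. Compound 3 `CCCCCCCCCCCC[C@@H](O)[C@H]1CC[C@H]([C@H](O)CCCCCCCCCCC(=O)Nc2ccnn2C)O1` differs from compound 2 as follows: (1-methyl-1H-pyrazol-5-yl)carbamoyl in place of ((1-methyl-1H-pyrazol-5-yl)methyl)amino on a saturated chain carbon, ten or more bonds along the chain from an oxygen on a saturated carbon and a saturated ring carbon. Going by the values given here, only one measured step bears on this change: a 3.6-fold lower number from compound 1 to compound 2 (0.56 log units; beyond the scatter). That modest step replaced a (1-methyl-1H-pyrazol-5-yl)carbonyl on an amine nitrogen with a (1-methyl-1H-pyrazol-5-yl)methyl. Among the compounds with values here, compound 3 regains a carbonyl, as a (1-methyl-1H-pyrazol-5-yl)carbamoyl, but this is not the same group as the one in compound 1. Within the data shown here, no measured compound yet shows what this different amide does, so the guidance is indirect. Read in reverse, the step from compound 1 suggests a modest move towards a higher number, and the range must stay wide. The expected change is a 2.5-fold higher number from compound 2 to compound 3 (0.40 log units; beyond the scatter). For compound 3, the estimated value is 4000 nM, with an expected range of 1500 nM to 11000 nM.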

Compound 3, concentration for 50% growth inhibition: 100000 nM
Beside the measured number, compound 3's estimate is 25-fold (1.40 log units) below it; measured number outside the range, above it.
By their numbers in this assay, from the lowest: compound 2; then compound 1; then compound 3.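

In this assay this position proves far more sensitive than the earlier pair suggested: with (1-methyl-1H-pyrazol-5-yl)carbamoyl in place of ((1-methyl-1H-pyrazol-5-yl)methyl)amino on the saturated chain carbon, there is a 63-fold higher number from compound 2 to compound 3 (1.80 log units; beyond the scatter), which makes compound 3 the weakest inhibitor of growth of the three. Having a carbonyl in the linking group does not by itself set the number, since compound 1 and compound 3 both carry an amide, yet the change from ((1-methyl-1H-pyrazol-5-yl)carbonyl)amino to (1-methyl-1H-pyrazol-5-yl)carbamoyl brings a 17-fold higher number from compound 1 to compound 3 (1.24 log units; beyond the scatter), so the way the amide is arranged on the chain matters a great deal in these compounds. No evidence is available to explain either step.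

From the compounds shown here alone, with only these three compounds, all sharing one core and one pyrazole group, it remains open whether the large loss belongs to the carbamoyl arrangement in general or to its direct attachment to the pyrazole ring. A urea or a sulfonamide at this chain end, or a methylene group inserted between the amide nitrogen and the ring, would help separate these possibilities, and a longer chain would show whether the loss persists at a different distance from the core.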